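Bromo for methoxy on the core of compound 1

A few compounds are considered here, and "the series" means these few. Any claim that something is new, unique, unknown or untested is made for them only; others in the source may bear on it.

Values in an ADME assay on MT4 cells (Homo sapiens) for cytotoxicity, read by MTT assay, with a stated time of 96 h (a lower number here means that less compound is tolerated, a higher number that more compound is tolerated), are these:
compound 1 (`COc1ccc(/N=N/N2CCCC2)cc1`) gives 68000 nM
compound 2 (`CN(C)CCCNc1ccc(/N=N/c2ccccc2)cc1`) gives 17000 nM
compound 3 (`Cc1c(/N=N/c2cccc(C(F)(F)F)c2)ccc(NC[C@@H]2CCCN3CCCC[C@H]23)c1C`) gives 77000 nM

Compound 1 at 68000 nM lies within the scatter of compound 3 at 77000 nM and sits clearly apart from compound 2 at 17000 nM on the lower side, a gap beyond the scatter. Still unmeasured is compound 4 (`Brc1ccc(/N=N/N2CCCC2)cc1`), which keeps the core of compound 1 and carries bromo in place of methoxy on an aromatic carbon, para to a group of 7 heavy atoms (bromo in place of methoxy on an aromatic carbon).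

For the measured compounds named here, no measured pair isolates this exchange, and neither compound 2 nor compound 3 carries the core of compound 1. Going by the values given here, the expectation therefore rests on compound 1 at 68000 nM and on the spread of the series down to compound 2 at 17000 nM as its only guide to range. The estimated 1.5-fold lower number from compound 1 to compound 4 (0.18 log units; within the scatter) is a modest downward move in this assay and is expected to stay within the scatter. Compound 4 is estimated at 45000 nM (expected range 15000 nM to 100000 nM).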

Compound 4, half-maximal cytotoxic concentration: > 100000 nM
Compound 4: a limit, no number; the forecaster's own chance of this, stated with the estimate: 20%; middle value at least 2.2-fold (0.34 log units) from the limit.
By their numbers in this assay, from the lowest: compound 2; then compounds 1 and 3 (each within the scatter of the next). At a limit, above all of these: compound 4.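

In this assay compound 4 gives > 100000 nM, which is a limit of the assay and not a number. Bromo in place of methoxy on an aromatic carbon, para to a group of 7 heavy atoms, is the first change in the series that can be read in one place, and it gives an at least 1.4-fold higher number from compound 1 to compound 4 (0.16 log units; that floor lies within the scatter). Going by these compounds, this position therefore accepts the exchange with no loss of tolerated concentration in this assay, but the floor of the step does not establish a real rise, and its true size stays open, the reading being a limit: the limit of > 100000 nM in this assay, at which 1 of the 4 values shown sits.

The compounds shown carry only methoxy and bromo at this place on the shared core, so it remains open how an amine, a carboxylic acid or a longer chain there would read in this assay. Compound 2 and compound 3 do not share the core of compound 1, so they cannot show whether the exchange would behave the same way on another core.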